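Microsomal half-life across an imidazole-amide series

A few compounds are considered here, and "the series" means these few. Any claim that something is new, unique, unknown or untested is made for them only; others in the source may bear on it.

Measured compounds:
compound 1 `Cn1c(-c2ccccc2)cnc1NC(=O)c1ncc[nH]1`: 1.47 h
compound 2 `COc1ccc(-c2cnc(NC(=O)c3ccc(F)cc3)n2C)cc1`: 0.983 h

In an ADME assay on microsomes from liver (Homo sapiens) for metabolic stability (on this read-out lower numbers stand for a shorter-lived compound and higher numbers for a longer-lived compound), compound 1 gives 1.47 h. In this assay compound 2 gives 0.983 h, the lowest of the two numbers, though the gap to compound 1 lies within the scatter, so no order between the two can be read from it.

The next step goes from compound 2 to compound 3 `COc1ccc(-c2cnc(NC(=O)c3ncc[nH]3)n2C)cc1`, which is not yet measured in this assay. The change is 1H-imidazol-2-yl in place of 4-fluorophenyl on a carbonyl carbon; the rest of the shared core is kept.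

Among the compounds with values here, no step between measured compounds covers this change, so its size must be guessed. Compound 1 carries the same 1H-imidazol-2-yl on the carbonyl carbon and gives 1.47 h, a number a little above compound 2 but within the scatter. The step from compound 2 to compound 3 is therefore expected to be small, likely upward, and not clearly beyond the scatter: a 1.3-fold higher number from compound 2 to compound 3 (0.12 log units; within the scatter). For compound 3 a half-life of 1.3 h is estimated, with a range from 0.6 h to 2.8 h.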

Compound 3, half-life in the Homo sapiens assay: > 4.25 h
Compound 3 gave a limit, no number; the forecaster's own chance of this, stated with the estimate: 5%; middle value at least 3.2-fold (0.51 log units) away from the limit.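

Within the data shown here, in the Homo sapiens assay, 1H-imidazol-2-yl in place of 4-fluorophenyl on a carbonyl carbon gives an at least 4.3-fold higher number from compound 2 to compound 3 (0.63 log units; beyond the scatter), and methoxy in place of hydrogen on an aromatic carbon gives an at least 2.8-fold higher number from compound 1 to compound 3 (0.46 log units; beyond the scatter), so each of these two single changes now has a step of its own beyond the scatter, which the earlier compounds could not supply. In a physicochemical assay for solubility, read by nephelometry, measured as kinetic solubility, at pH 6.5 (on this read-out higher numbers stand for higher solubility and lower numbers for lower solubility), compound 2 gives < 1.6 ug/mL, which is a limit of the assay and not a number. In the physicochemical assay compound 3 gives 6.3 ug/mL, and the same change on the carbonyl carbon gives an at least 3.9-fold higher number from compound 2 to compound 3 (0.59 log units; beyond the scatter), so for this one pair the step points upward in both read-outs.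

Going by these compounds, the true size of the steps stays open, since compound 3 reads only as a limit in half-life: the limit of > 4.25 h in the Homo sapiens assay, at which 1 of the 3 values shown sits. Whether the upward steps belong to 1H-imidazol-2-yl in particular also stays open, and a pyridyl group or a methyl-substituted imidazolyl group on the same carbonyl carbon would test this.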